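The source may report more compounds than this note shows. Statements on the series, on what has been measured and on what is new or still open speak of the compounds shown alone.

Measured so far:
compound 1, `COc1cccc(CNCCCNc2ccnc3cc(CCC(C)C)ccc23)c1O`: 23 10^-6 cm/s
compound 2, `COc1cccc(CNCCCNc2ccnc3cc(Cc4cccc(C(F)(F)F)c4)ccc23)c1O`: 23 10^-6 cm/s
compound 3, `COc1ccc(F)cc1CNCCCNc1ccnc2cc(Cc3cccc(C(F)(F)F)c3)ccc12`: 23 10^-6 cm/s

In an ADME assay for permeability, using PAMPA, with a stated time of 30 min, at pH 7.4 (on this read-out higher numbers stand for higher permeability and lower numbers for lower permeability), the three measured compounds stand at one level. Compound 1 gives 23 10^-6 cm/s, compound 2 gives 23 10^-6 cm/s, and compound 3 gives 23 10^-6 cm/s; none of these pairs is separated beyond the scatter.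

Two changes have been made among them. The first is isobutyl in place of 3-(trifluoromethyl)phenyl on a saturated chain carbon bound to an aromatic carbon, and it gave the step of no change at the digits printed from compound 2 to compound 1 (within the scatter). The second concerns the cores: compound 2 and compound 3 differ by 5-fluoro-2-methoxyphenyl in place of 2-hydroxy-3-methoxyphenyl on a saturated chain carbon bound to an amine nitrogen, and that gave the step of no change at the digits printed from compound 2 to compound 3 (within the scatter).

Compound 4, `COc1ccc(F)cc1CNCCCNc1ccnc2cc(CCC(C)C)ccc12`, is not yet measured. It differs from compound 3 by isobutyl in place of 3-(trifluoromethyl)phenyl on a saturated chain carbon bound to an aromatic carbon. The place of this change is described in the same words as for the change from compound 2 to compound 1, so it is the same change, here carried out on the core of compound 3 rather than on the core of compound 2. Among the compounds shown, this change occurs twice.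

In this assay the step of no change at the digits printed from compound 3 to compound 4 (within the scatter) is expected to be flat, because the same change gave no change at the digits printed from compound 2 to compound 1 (within the scatter) and the core of compound 3 sits level with the core of compound 2. The expectation rests on three compounds only, and on one prior instance of the change.

For compound 4 the estimated value is 23 10^-6 cm/s, with an expected range from 12 10^-6 cm/s to 45 10^-6 cm/s.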

Compound 4, apparent permeability: 23 10^-6 cm/s
For compound 4 middle estimate and measured number coincide at the digits printed; the range from low to high includes it.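

In this assay, isobutyl in place of 3-(trifluoromethyl)phenyl on a saturated chain carbon bound to an aromatic carbon gives no change at the digits printed from compound 3 to compound 4 (within the scatter), and this agrees with the earlier instance of the change: the same change on two cores in this assay, no change at the digits printed (within the scatter) from compound 2 to compound 1 and no change at the digits printed (within the scatter) from compound 3 to compound 4, 1.0-fold (0.00 log units) apart, within the scatter of two such steps

Likewise, 5-fluoro-2-methoxyphenyl in place of 2-hydroxy-3-methoxyphenyl on a saturated chain carbon bound to an amine nitrogen gives no change at the digits printed from compound 1 to compound 4 (within the scatter), again in agreement with the earlier instance: the same change on two cores in this assay, no change at the digits printed (within the scatter) from compound 2 to compound 3 and no change at the digits printed (within the scatter) from compound 1 to compound 4, 1.0-fold (0.00 log units) apart, within the scatter of two such steps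

Within these four compounds, each change therefore carries from one core to the other with no gap in this assay, but this is a transfer of flat steps only, seen once per change, and it does not show how a change that moves the value would carry over, nor whether either change stays flat on other cores.

Still open, going by these compounds, is whether an amine, a carboxylic acid or a longer chain in place of isobutyl would leave the value in this assay where it stands. On these data alone, all four compounds sit level, so what would separate members in this assay remains unknown.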